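Benzyl in place of butoxy: working notes on compound 4

This account rests on a few compounds, and the source may have more. Where it says the series, first, only, none or still open, it means among the compounds named here.

Of the compounds shown here, three have been read in a functional assay on U-251 cells (Homo sapiens) for inhibition, read by sulforhodamine B assay, with a stated time of 48 h; on this read-out lower numbers stand for stronger inhibition of growth and higher numbers for weaker inhibition of growth. Compound 1 `COc1ccc(NC(=O)Nc2n[nH]c3ccccc23)cc1` reaches only the limit of the assay there, > 100000 nM, which is a limit and not a number (the limit of > 100000 nM in this assay, at which 1 of the 3 values shown sits). Compound 2 `CCCCOc1ccc(NC(=O)n2nc(N)c3ccccc32)cc1` gives 30500 nM in this assay. Compound 3 `Nc1nn(C(=O)Nc2c(F)cccc2F)c2ccccc12` gives 96100 nM in this assay. Of the two numbers, compound 2 stands lowest; the nearest number is that of compound 3, and the gap between the two lies beyond the scatter. Going by the values given here, no pair of measured compounds differs in only one place, so no measured step is at hand to size a single change.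

Compound 4 `Nc1nn(C(=O)Nc2ccc(Cc3ccccc3)cc2)c2ccccc12` has not yet been measured. Against compound 2 it shows (benzyl in place of butoxy on an aromatic carbon). The expectation for this change is a step in this assay of modest size, not beyond what separates compound 2 from compound 3, and if anything toward lower numbers rather than higher. The step from compound 2 to compound 4 is estimated at a 1.7-fold lower number from compound 2 to compound 4 (0.23 log units; within the scatter). Compound 4 is expected to give 18000 nM in this assay, with a likely range from 5000 nM to 65000 nM.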

Compound 4, concentration for 50% growth inhibition: 13900 nM
Beside the measured number, compound 4's estimate is 1.3-fold (0.11 log units) above it; the range from low to high includes it.
By their numbers in this assay, from the lowest: compound 4; then compound 2; then compound 3. At a limit, above all of these: compound 1.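

In this assay, going by these compounds alone, this is the only measured step that changes a single place, which sizes one change directly for the first time: a 2.2-fold lower number from compound 2 to compound 4 (0.34 log units; beyond the scatter). The position on the six-membered aromatic ring of carbon only, para to a large group, therefore accepts benzyl in place of butoxy, and the number falls rather than rises. The exchange replaces an open chain holding one hydrogen-bond acceptor with a group holding an aromatic ring and no hydrogen-bond acceptor, so in this pair the oxygen of butoxy is not needed to reach the lower number.

This single pair cannot separate the part played by the added ring, the higher heavy-atom count or the lost oxygen, and nothing measured here accounts for the size of the step. From the compounds shown here alone, a phenoxy group, which would keep an aromatic ring and restore an oxygen, and a plain pentyl chain, which would keep an open chain without an oxygen, remain open at this position and could help separate these changes.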